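Swapping a Methyl for Trifluoromethyl on the Side-Chain Ring

This account rests on a few compounds, and the source may have more. Where it says the series, first, only, none or still open, it means among the compounds named here.

Measured compounds:
- compound 1, `C#CCNC1CCc2c(SCCc3ccc(C)cc3)cccc21`: 25800 nM
- compound 2, `C#CCNC1CCc2c(SCCc3cccc(Cl)c3)cccc21`: 82400 nM
- compound 3, `C#CCNC1CCc2c(SCCc3cccc(OC)c3)cccc21`: 28700 nM

All three share one core and differ only in the ring at the end of the sulfur-linked chain. In an assay on isolated protein for inhibition of Amine oxidase [flavin-containing] B (Homo sapiens) (on this read-out lower numbers stand for stronger inhibition and higher numbers for weaker inhibition), compound 1 gives the lowest of the three numbers; compound 3 sits within the scatter of it, while compound 2 lies further off, as the step of a 3.2-fold higher number from compound 1 to compound 2 (0.50 log units; beyond the scatter) shows. Moving from compound 2 to compound 3 gives a 2.9-fold lower number from compound 2 to compound 3 (0.46 log units; beyond the scatter), and from compound 1 to compound 3 only a 1.1-fold higher number from compound 1 to compound 3 (0.05 log units; within the scatter).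

The new compound 4, `C#CCNC1CCc2c(SCCc3ccc(C(F)(F)F)cc3)cccc21`, differs from compound 1 by trifluoromethyl in place of methyl on an aromatic carbon, on an aromatic carbon of a six-membered aromatic ring of carbon only, para to a large group. Among the measured compounds shown here, none of the measured steps changes that same position; they only show that altering this ring moves this assay by modest amounts at most. For compound 4 the expected step is therefore small, a 1.4-fold higher number from compound 1 to compound 4 (0.13 log units; within the scatter), with no firm direction. Compound 4 is thus estimated at 35000 nM, in a range from 12000 nM to 100000 nM.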

Compound 4, half-maximal inhibitory concentration: 16100 nM
Estimate against measurement, compound 4: 2.2-fold (0.34 log units) above; the measured number falls inside the stated range.
By their numbers in this assay, from the lowest: compounds 4, 1 and 3 (each within the scatter of the next); then compound 2.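

In this assay, putting trifluoromethyl in place of methyl on this aromatic carbon gives a 1.6-fold lower number from compound 1 to compound 4 (0.20 log units; within the scatter), so compound 1 and compound 4 cannot be told apart. Among the compounds shown here, this is the first direct test of this position: the earlier steps changed the group and its place on the ring together, whereas here the place stays the same and only the group changes. A group of 4 heavy atoms can therefore replace one of 1 heavy atom here without a change beyond the scatter, although nothing available explains this result.

From the compounds shown here alone, it remains open whether an amine or a carboxylic acid at this same place would also leave the number within the scatter of compound 1. The effect of a longer chain between the sulfur and the ring is also unknown.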